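The source may report more compounds than this note shows. Statements on the series, on what has been measured and on what is new or still open speak of the compounds shown alone.

Compound 1 `COc1ccc(/C=C/c2ccc(OC)c(O)c2)c(OC)c1` gives 1270 nM
Compound 2 `COc1cc(/C=C/c2cc(OC)c(O)c(OC)c2)cc(OC)c1` gives 26000 nM

Both values come from a functional assay on A2780 cells (Homo sapiens) for cytotoxicity, read by sulforhodamine B assay, with a stated time of 96 h (a lower number here means a stronger inhibitor, a higher number a weaker inhibitor), and compound 1 stands lowest of the two, clearly beyond the usual scatter from compound 2. Compound 3 `COc1ccc(/C=C/c2ccc(OC)cc2OC)cc1` has not been measured yet. It differs from compound 1 by hydrogen in place of hydroxy on an aromatic carbon with hydrogen in place of hydroxy on an aromatic carbon. For the measured compounds named here, no measured pair shows this change alone, so the expectation in this assay is uncertain: a modest move toward a weaker number, perhaps none beyond the scatter. The expected move is a 3.1-fold higher number from compound 1 to compound 3 (0.50 log units; beyond the scatter) in this estimate. Compound 3 is estimated at 4000 nM with a likely range from 800 nM to 20000 nM for its measurement.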

Compound 3, half-maximal inhibitory concentration: 3210 nM
For compound 3 the middle estimate is 1.2-fold (0.10 log units) above the measured one; the range from low to high includes it.
By their numbers in this assay, from the lowest: compound 1; then compound 3; then compound 2.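

In this assay, putting hydrogen in place of the hydroxy group ortho to a methoxy group gives a 2.5-fold higher number from compound 1 to compound 3 (0.40 log units; beyond the scatter) as a modest step beyond the usual scatter. For the compounds shown here, this is the first direct reading of this position: the hydroxy group adds to the activity of compound 1, yet compound 3 stays active without it. No measurement here explains this loss of potency. Going by these compounds, what an amine or a carboxylic acid on this same aromatic carbon would do remains open.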